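The compounds below may be only part of what the source reports. "The series", "measured", "known", "first", "only" and "open" are said of these compounds alone.

Measured so far:
- compound 1 `CCN(CC)C(=O)Nc1ccc(S(=O)(=O)Nc2cccc(-c3nc(-c4ccc(NC(=O)c5cccnc5)cc4Cl)no3)c2)cc1`: 8700 nM
- compound 2 `NS(=O)(=O)c1ccc(NC(=O)Nc2cccc(-c3nc(-c4ccc(NC(=O)c5cccnc5)cc4Cl)no3)c2)cc1`: > 10000 nM

In a functional assay on MDA-MB-231 cells (Homo sapiens) for antiproliferative activity, read by MTT assay, with a stated time of 72 h (on this read-out lower numbers stand for stronger inhibition and higher numbers for weaker inhibition), compound 1 gives 8700 nM. For compound 2 the assay reports only a limit, > 10000 nM, and no number is known for it. Its place is told by the limit of > 10000 nM in this assay, at which 1 of the 2 values shown sits. Of the pair, only this much can be said: compound 1 has a number, compound 2 does not, and neither reaches a potent value.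

Compound 3 `CS(=O)(=O)Nc1cccc(NC(=O)Nc2cccc(-c3nc(-c4ccc(NC(=O)c5cccnc5)cc4Cl)no3)c2)c1` is not yet measured in this assay. It differs from compound 2 in one place: 3-(methanesulfonamido)phenyl in place of 4-sulfamoylphenyl on an amide-type nitrogen. Among the compounds with values here, no measured pair differs in the same way, so no measured step sets the direction. Both compound 2 and compound 3 carry a sulfonamide-bearing phenyl on the urea nitrogen, and the shared core is unchanged.

Compound 3 is expected to give about 9000 nM in this assay, with a range from 3000 nM to 30000 nM. The step this estimate means, an at least 1.1-fold lower number from compound 2 to compound 3 (0.04 log units; that floor lies within the scatter), is expected to stay within the scatter, and a limit rather than a number is about as likely as not.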

Compound 3, half-maximal inhibitory concentration: > 10000 nM
Compound 3 ended at the assay's limit; the forecaster's own chance of this, stated with the estimate: 45%; middle value at least 1.1-fold (0.04 log units) away from the limit.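

No step can be read between compound 2 and compound 3 in this assay, since each gives only a limit and no number: the limit of > 10000 nM in this assay, at which 2 of the 3 values shown sit.

Still open, from the compounds shown here alone, is how far 3-(methanesulfonamido)phenyl and 4-sulfamoylphenyl on an amide-type nitrogen differ in this read-out, and in which direction.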